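The source may hold more compounds than are shown below. What is called first, only, known or untested is meant among the compounds shown, and "the series" means these compounds.

Of the compounds shown here, three sharing one core have been measured in a physicochemical assay for solubility, measured as kinetic solubility; a higher number here means a more soluble compound, a lower number a less soluble compound: compound 1 `O=C(Nc1ccnnc1)c1cc(N2C[C@H]3COC[C@H]3C2)ccc1OCc1ccccc1` gives 57000 nM, compound 2 `CN1CCC(c2ccc(OCc3ccccc3)c(C(=O)Nc3ccnnc3)c2)CC1` gives 71000 nM, and compound 3 `C[C@@H]1CN(c2ccc(OCc3ccccc3)c(C(=O)Nc3ccnnc3)c2)C[C@H](C)O1` gives 29000 nM. The standing of the last of these is mixed: a 2.0-fold lower number from compound 1 to compound 3 (0.29 log units; within the scatter) lies within the scatter, whereas a 2.4-fold lower number from compound 2 to compound 3 (0.39 log units; beyond the scatter) goes beyond it, though only modestly. The third comparison, a 1.2-fold higher number from compound 1 to compound 2 (0.10 log units; within the scatter), also stays within the scatter. Compound 4 `CN1CC2(C1)CN(c1ccc(OCc3ccccc3)c(C(=O)Nc3ccnnc3)c1)C2` remains unmeasured, and its structure differs from the preceding one as follows: a group of 8 heavy atoms (6 carbon, 2 nitrogen; 2 four-membered non-aromatic rings with 1 hetero atom each) in place of a group of 8 heavy atoms (6 carbon, 1 nitrogen, 1 oxygen; one six-membered non-aromatic ring with 2 hetero atoms), on an aromatic carbon. Among the compounds with values here, no measured step covers this exact exchange. Like the 1-methylpiperidin-4-yl group of compound 2, which gives 71000 nM, the entering group holds no oxygen, so a modest rise in this assay is expected, similar in size to a 2.4-fold lower number from compound 2 to compound 3 (0.39 log units; beyond the scatter) but in reverse. This is only a loose guide, since the ring sizes differ. The expected change is a 2.2-fold higher number from compound 3 to compound 4 (0.35 log units; beyond the scatter). For compound 4 the estimate is 65000 nM, with an expected range of 28000 nM to 150000 nM.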

Compound 4, solubility: 198000 nM
The estimate for compound 4 lay 3.0-fold (0.48 log units) below the measured number; measured number above the stated range.
By their numbers in this assay, from the lowest: compounds 3, 1 and 2 (each within the scatter of the next, the first and the last beyond it); then compound 4.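

In this assay, the group with 2 four-membered non-aromatic rings, on the aromatic carbon para to a benzyloxy group, gives a 6.8-fold higher number from compound 3 to compound 4 (0.83 log units; beyond the scatter), a 2.8-fold higher number from compound 2 to compound 4 (0.45 log units; beyond the scatter) and a 3.5-fold higher number from compound 1 to compound 4 (0.54 log units; beyond the scatter), so compound 4 stands beyond the scatter of all three earlier compounds. Before it, the only step at this position beyond the scatter was a 2.4-fold lower number from compound 2 to compound 3 (0.39 log units; beyond the scatter), and since the group in compound 2 also holds no oxygen, the absence of oxygen alone does not account for the number of compound 4. No measurement shown offers an explanation for this rise.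

From the compounds shown here alone, it remains open whether the step follows the four-membered rings themselves or the placing of the nitrogen within them. The compounds shown also leave open how a secondary amine or an open-chain dimethylamino group would read at this position.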